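The source may report more compounds than this note shows. Statements on the series, on what has been measured and on what is new or still open speak of the compounds shown alone.

Measured compounds:
- compound 1 `O=c1cc(-c2ccccc2)oc2ccc(N3COc4ccccc4C3)cc12` — 92.7%
- compound 2 `Cc1cccc2c1OCN(c1ccc3c(=O)cc(-c4ccccc4)oc3c1)C2` — 66.6%
- compound 3 `Cc1ccc2c(c1)CN(c1ccc3oc(-c4ccccc4)cc(=O)c3c1)CO2` — 79.5%

In a functional assay on MCF7 cells (Homo sapiens) for inhibition, read by MTT assay, with a stated time of 48 h, tested at 60 ug/mL (a lower number here means less inhibition of growth, a higher number more inhibition of growth at the concentration tested), compound 1 gives 92.7%. Compound 3 gives 79.5% in this assay, and compound 2 gives 66.6%. Compound 2 has the lowest of the three numbers, with compound 3 the nearest and compound 1 the furthest, both beyond the scatter.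

One structural change recurs. Going from compound 3 to compound 1 the change is hydrogen in place of methyl on an aromatic carbon. This step is a number 13.2 percentage points higher from compound 3 to compound 1 (beyond the scatter). Compound 2 and compound 3 are built from the same atoms joined differently; the difference between these two cores is not broken down here.

Compound 4 `O=c1cc(-c2ccccc2)oc2cc(N3COc4ccccc4C3)ccc12` has not yet been measured in this assay. It differs from compound 2 by hydrogen in place of methyl on an aromatic carbon. This is the same kind of change as from compound 3 to compound 1, but not the same: on the core of compound 3 the place is meta to a fused ring and para to a fused ring, whereas on the core of compound 2 it is ortho to a fused ring and meta to a fused ring. The change occurs twice among the compounds shown, once measured and once pending.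

The expectation rests on a single precedent. Because the step of a number 13.2 percentage points higher from compound 3 to compound 1 (beyond the scatter) was modest and beyond the scatter, a step of similar size is expected for compound 4, namely a number 12.4 percentage points higher from compound 2 to compound 4 (beyond the scatter). The estimate for compound 4 in this assay is 79%, with a likely range from 66% to 91%. Among the measured compounds shown here, the range is set wide, since the place of the change differs between the two cores and only one measured step informs it.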

Compound 4, percent growth inhibition at one concentration: 19.3%
For compound 4 the middle estimate is 59.7 percentage points above the measured one; measured number outside the range, below it.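

The new step in this assay is a number 47.3 percentage points lower from compound 2 to compound 4 (beyond the scatter), so hydrogen in place of methyl on an aromatic carbon does not carry over from one core to the other with either its size or its direction, and the earlier step gives no usable guide on the core of compound 2: the same change on two cores in this assay, a number 13.2 percentage points higher (beyond the scatter) from compound 3 to compound 1 and a number 47.3 percentage points lower (beyond the scatter) from compound 2 to compound 4, 60.5 percentage points apart, beyond the scatter of two such steps. On the core of compound 2, the methyl-bearing compound 2 is therefore the one with the higher growth inhibition, while on the core of compound 3 the hydrogen compound, compound 1, holds that place. These two pairs do not show why the steps part, nor whether the core itself or the different place of the change (on the core of compound 2, ortho to a fused ring and meta to a fused ring) is what matters, and with one pair per core neither step can be taken as a general rule for that core.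

As far as these compounds go, it remains open how an ethyl group, a methoxy group or a chlorine atom on the same aromatic carbon would read on each core, and whether any of them would follow methyl or hydrogen. Also open is whether the opposite steps persist away from the single concentration tested, since a full concentration series on these pairs is not among the data shown.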